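Ring groups on the aromatic nitrogen of the shared core

The source may report more compounds than this note shows. Statements on the series, on what has been measured and on what is new or still open speak of the compounds shown alone.

Among the measured compounds shown here, compound 1 `CCn1c(-c2ccc(OCc3c(-c4c(Cl)cccc4Cl)noc3C(C)C)cc2)nc2ccc(C(=O)O)cc21` gives 5760 nM in an assay on HEK-293T cells for antagonist activity at vitamin D3 receptor (Homo sapiens), read by a luciferase reporter, with a stated time of 24 h (on this read-out higher numbers stand for weaker inhibition and lower numbers for stronger inhibition), the highest of the three numbers measured so far. Compound 2 `CC(C)c1onc(-c2c(Cl)cccc2Cl)c1COc1ccc(-c2nc3ccc(C(=O)O)cc3n2-c2ccc(F)cc2)cc1` gives 2410 nM in this assay and compound 3 `CC(C)c1onc(-c2c(Cl)cccc2Cl)c1COc1ccc(-c2nc3ccc(C(=O)O)cc3n2C2CCCCC2)cc1` gives 1450 nM. Both measured steps away from compound 1 lower the number: a 2.4-fold lower number from compound 1 to compound 2 (0.38 log units; beyond the scatter) and a 4.0-fold lower number from compound 1 to compound 3 (0.60 log units; beyond the scatter). Between compound 2 and compound 3 the step is a 1.7-fold lower number from compound 2 to compound 3 (0.22 log units; within the scatter).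

Compound 4 `CC(C)c1onc(-c2c(Cl)cccc2Cl)c1COc1ccc(-c2nc3ccc(C(=O)O)cc3n2C2CCCC2)cc1` has not yet been measured in this assay. It differs from compound 1 in one place: cyclopentyl in place of ethyl on an aromatic nitrogen. The step from compound 1 to compound 3 bears on it most directly, cyclohexyl and cyclopentyl both being non-aromatic rings of carbon only entering in place of ethyl on the aromatic nitrogen; the step from compound 1 to compound 2 shows that a ring of another kind at that nitrogen also lowers the number. A modest lowering beyond the scatter is therefore expected for compound 4, a 3.2-fold lower number from compound 1 to compound 4 (0.51 log units; beyond the scatter), of about the size of the cyclohexyl step or somewhat smaller. The estimated value for compound 4 in this assay is 1800 nM, with a range from 900 nM to 3600 nM.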

Compound 4, half-maximal inhibitory concentration: 929 nM
Compound 4: middle estimate off by 1.9-fold (0.29 log units), on the high side; the range from low to high includes it.
By their numbers in this assay, from the lowest: compounds 4, 3 and 2 (each within the scatter of the next, the first and the last beyond it); then compound 1.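

Taking the ring down to cyclopentyl keeps the gain over ethyl and enlarges the measured effect at this aromatic nitrogen, with a 6.2-fold lower number from compound 1 to compound 4 (0.79 log units; beyond the scatter) in this assay. Five-membered and six-membered carbon rings are not separated here, as a 1.6-fold lower number from compound 3 to compound 4 (0.19 log units; within the scatter) lies within the scatter, so no preference between those two ring sizes can be claimed. Cyclopentyl is the first non-aromatic ring to separate from the 4-fluorophenyl group, with a 2.6-fold lower number from compound 2 to compound 4 (0.41 log units; beyond the scatter), but cyclohexyl in compound 3 goes against any general ranking of non-aromatic over aromatic rings, since it stays within the scatter of compound 2, and no measurement at hand offers an explanation for these differences.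

The compounds shown cannot tell whether the ring itself matters or only the larger carbon group, a question that an open chain such as pentyl or a branched group such as isopropyl would bear on. Smaller carbon rings such as cyclopropyl and cyclobutyl, and rings holding oxygen or nitrogen such as tetrahydropyranyl or piperidinyl, also remain open at this position.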